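From Isopropyl to Phenyl on a Selenocyanate Carbamate

This account rests on a few compounds, and the source may have more. Where it says the series, first, only, none or still open, it means among the compounds named here.

Compound 1 `CC(C)COC(=O)Nc1ccc([Se]C#N)cc1`: 21600 nM
Compound 2 `CCCCCCOC(=O)Nc1ccc([Se][Se]c2ccc(NC(=O)OCCCCCC)cc2)cc1`: 600 nM
Compound 3 `O=C(Nc1ccc([Se][Se]c2ccc(NC(=O)Oc3ccccc3)cc2)cc1)Oc1ccccc1`: 5300 nM

Of the compounds shown here, three have been tested in a functional assay on PC-3 cells (Homo sapiens) for cytotoxicity, read by MTT assay, with a stated time of 72 h; a lower number here means a stronger inhibitor of growth, a higher number a weaker inhibitor of growth. Compound 1 stands at the highest of the three numbers: compound 3 gives a lower number, and compound 2 a lower number still, and both gaps lie beyond the usual scatter of this assay. Going by the values given here, compounds 2 and 3 differ from compound 1 in more than one place, so no single step between any two measured compounds is known.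

The compound to be measured next is compound 4 `N#C[Se]c1ccc(NC(=O)OCc2ccccc2)cc1`. It differs from compound 1 in one place: phenyl in place of isopropyl on a saturated chain carbon bound to an oxygen next to a carbonyl group. Among the compounds with values here, no measured pair shows this exact change, so its effect on this assay is uncertain. Resting only on compound 1, which gives 21600 nM, the expectation is a modest step, more likely toward a lower number, and possibly none beyond the scatter. Compound 4 is expected to give about 12000 nM, with a likely range from 4000 nM to 40000 nM. The step this estimate means is a 1.8-fold lower number from compound 1 to compound 4 (0.26 log units; within the scatter).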

Compound 4, concentration for 50% growth inhibition: 3700 nM
The estimate for compound 4 lay 3.2-fold (0.51 log units) above the measured number; measured number outside the range, below it.
By their numbers in this assay, from the lowest: compound 2; then compounds 4 and 3 (each within the scatter of the next); then compound 1.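

Going by these compounds alone, this is the first step that changes only one place. In this assay phenyl in place of isopropyl on a saturated chain carbon bound to an oxygen next to a carbonyl group gives a 5.8-fold lower number from compound 1 to compound 4 (0.77 log units; beyond the scatter) and that step lies beyond the scatter. What this position carries therefore matters for growth inhibition, something compounds 2 and 3 could not show, since each differs from compound 1 in more than one place. Nothing measured here says why the number falls.

A single step cannot separate the effect of the aromatic ring from that of the larger count of heavy atoms, and a cyclohexyl group at this position would bear on that question. Going by these compounds, whether an amine or a carboxylic acid would be tolerated here also remains open.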